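Esterifying compound 3: a step away from the limit

The compounds below may be only part of what the source reports. "The series", "measured", "known", "first", "only" and "open" are said of these compounds alone.

In a functional assay on Hs 683 cells (Homo sapiens) for inhibition, read by MTT assay, with a stated time of 72 h (a higher number here means a weaker inhibitor, a lower number a stronger inhibitor), compound 1 `CCc1oc([C@H](C)/C=C(\C)[C@H](OC(C)=O)[C@H](C)[C@@H](OC(=O)CC(C)C)[C@@H](C)c2oc([C@@H](C)[C@H](CC)OC(C)=O)c(C)c(=O)c2C)c(C)c(=O)c1C` gives 24000 nM. Compound 2 `CCC(=O)[C@@H](C)c1oc([C@H](C)[C@@H]2O[C@](O)([C@@H](C)c3oc(CC)c(C)c(=O)c3C)[C@@H](C)[C@@H](O)[C@@H]2C)c(C)c(=O)c1C` reads > 100000 nM, which is a limit and not a number. Compound 3 `CCC(=O)[C@H](C)c1oc([C@H](C)[C@@H]2O[C@](O)([C@@H](C)c3oc(CC)c(C)c(=O)c3C)[C@@H](C)[C@@H](O)[C@@H]2C)c(C)c(=O)c1C` reads > 100000 nM, also a limit, so it offers no number to step from. Compound 4 `CCC(=O)[C@H](C)c1oc([C@H](C)[C@@H]2O[C@](O)([C@@H](C)c3oc(CC)c(C)c(=O)c3C)[C@@H](C)[C@@H](OC(=O)CC(C)C)[C@@H]2C)c(C)c(=O)c1C` differs from compound 3 by isobutylcarbonyl in place of hydrogen on an oxygen on a saturated carbon, that is, hydroxy to (isobutylcarbonyl)oxy. Going by the values given here, the only measured step is a step that the two limits leave unreadable from compound 2 to compound 3; it reflects the fact that compounds 2 and 3 differ only in the configuration as drawn and gives no size for this change. Among the compounds with values here, the one guide is compound 1, which also carries (isobutylcarbonyl)oxy and gives 24000 nM. Stronger inhibition is therefore expected, with the estimated move being an at least 2.5-fold lower number from compound 3 to compound 4 (0.39 log units; beyond the scatter). The estimate for compound 4 is 40000 nM, with an expected range of 10000 nM to 100000 nM.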

Compound 4, half-maximal inhibitory concentration: 23000 nM
Estimate against measurement, compound 4: 1.7-fold (0.24 log units) above; the measured number falls inside the stated range.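

In this assay, going by these compounds alone, isobutylcarbonyl in place of hydrogen on this oxygen gives the first readable change at this position: an at least 4.3-fold lower number from compound 3 to compound 4 (0.63 log units; beyond the scatter). Compound 3 reads > 100000 nM, which is a limit and not a number, so the true step may be larger. In this pair, the free hydroxy is not needed for a measurable value.

On these data alone, whether a longer chain such as decanoyl, or an amine on the ester chain, would move the value further remains open. Also open, as far as these compounds go, is whether the same ester on compound 2 would give a similar step, since the step between compound 2 and compound 3 cannot be read.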